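This account rests on a few compounds, and the source may have more. Where it says the series, first, only, none or still open, it means among the compounds named here.

Measured compounds:
- compound 2, `NS(=O)(=O)c1cccc(/N=C2\NC(=O)/C(=C3/C(=O)Nc4ccc(Br)cc43)S2)c1`: in a functional assay on Caco-2 cells (Homo sapiens) for antiproliferative activity, read by MTT assay (a higher number here means a weaker inhibitor, a lower number a stronger inhibitor), compound 2 gives 10800 nM
- compound 3, `NS(=O)(=O)c1ccc(/N=C2\NC(=O)/C(=C3/C(=O)Nc4ccc(Cl)cc43)S2)cc1`: compound 3 gives 20300 nM
- compound 1, `CN1C(=O)/C(=C2\S/C(=N/c3ccc(S(N)(=O)=O)cc3)NC2=O)c2cc(Cl)ccc21`: compound 1 gives 42300 nM

Compound 2 has the lowest number of the three; its gap to compound 3 lies within the scatter, while its gap to compound 1 lies beyond it. Going by the values given here, the only measured one-place step, a 2.1-fold lower number from compound 1 to compound 3 (0.32 log units; beyond the scatter), concerns hydrogen in place of methyl on an amide-type nitrogen in a ring and says nothing about the bromo group. Compound 4, `NS(=O)(=O)c1cccc(/N=C2\NC(=O)/C(=C3/C(=O)Nc4ccc([N+](=O)[O-])cc43)S2)c1`, differs from compound 2 by nitro in place of bromo on an aromatic carbon. Among the compounds with values here, no measured step touches that substituent, so the expectation for compound 4 is a step of about a 1.1-fold higher number from compound 2 to compound 4 (0.05 log units; within the scatter) in this assay, nothing beyond the scatter. Compound 4 is therefore estimated at 12000 nM, within 4000 nM to 40000 nM.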

Compound 4, half-maximal inhibitory concentration: 20600 nM
Beside the measured number, compound 4's estimate is 1.7-fold (0.23 log units) below it; the measured number falls inside the stated range.
By their numbers in this assay, from the lowest: compounds 2, 3 and 4 (each within the scatter of the next); then compound 1.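

On this aromatic carbon, nitro in place of bromo gives a 1.9-fold higher number from compound 2 to compound 4 (0.28 log units; within the scatter) in this assay, the only step shown that touches this substituent. Three heavy atoms and two hydrogen-bond acceptors thus enter in place of a single bromine, yet the two compounds cannot be told apart in this read-out. Nothing available explains this result.

As far as these compounds go, whether an amine or a carboxylic acid on this carbon would give a step beyond the scatter remains open. So does whether plain hydrogen there would.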